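Removing the Trifluoromethyl from the Amide of Compound 1

The source may report more compounds than this note shows. Statements on the series, on what has been measured and on what is new or still open speak of the compounds shown alone.

Measured compounds in a functional assay on OVCAR-8 cells (Homo sapiens) for inhibition, read by sulforhodamine B assay, with a stated time of 48 h; a lower number here means a stronger inhibitor of growth, a higher number a weaker inhibitor of growth:
compound 1 `COc1cc(-c2nn(-c3cccc(NC(=O)c4cccc(C(F)(F)F)c4)c3)cc2-c2ccncc2)ccc1Cl` gives 2000 nM
compound 2 `COc1cc(-c2nn(-c3cccc(NC(=O)Nc4ccc(Cl)c(Cl)c4)c3)cc2-c2ccncc2)ccc1Cl` gives 931 nM
compound 3 `O=C(Nc1cccc(-n2cc(-c3ccncc3)c(-c3ccc(Cl)c(O)c3)n2)c1)Nc1cc(C(F)(F)F)cc(C(F)(F)F)c1` gives 563 nM

Among the three measured compounds, compound 1 has the highest number in this assay: compound 2 lies nearest, and compound 3 furthest. For the measured compounds named here, the only one-step change on record is a 2.1-fold lower number from compound 1 to compound 2 (0.33 log units; beyond the scatter), where the amide becomes a urea carrying a (3,4-dichlorophenyl)amino group. Compound 3 differs from compound 1 in more than one place, so its value shows only that it lies below both of the others.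

Compound 4 `COc1cc(-c2nn(-c3cccc(NC(=O)c4ccccc4)c3)cc2-c2ccncc2)ccc1Cl` is compound 1 with the change (hydrogen in place of trifluoromethyl on an aromatic carbon), so the (3-(trifluoromethyl)phenyl)carbonyl becomes a simple benzoyl. Going by the values given here, no measured step touches this trifluoromethyl, so nothing here speaks directly to its removal. Among the compounds with values here, the one recorded step concerns a different part of the molecule and was modest, which gives no ground to expect a large shift in either direction. Compound 4 is therefore expected to stay near compound 1, perhaps slightly weaker, as a 1.5-fold higher number from compound 1 to compound 4 (0.18 log units; within the scatter), with an estimate of 3000 nM between 1000 nM and 9000 nM.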

Compound 4, concentration for 50% growth inhibition: 995 nM
The estimate for compound 4 lay 3.0-fold (0.48 log units) above the measured number, outside the stated range (below it).
By their numbers in this assay, from the lowest: compounds 3, 2, 4 and 1 (each within the scatter of the next, the first and the last beyond it).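

In this assay, for the compounds shown here, this is the first reading at the trifluoromethyl position, and hydrogen is tolerated there: the step shows a 2.0-fold lower number from compound 1 to compound 4 (0.30 log units; within the scatter) and so stays inside the usual spread of repeats. The simple benzoyl also matches the urea, with a 1.1-fold higher number from compound 2 to compound 4 (0.03 log units; within the scatter), so neither the trifluoromethyl nor the (3,4-dichlorophenyl)amino group is required for a number in this range among these compounds. No measurement shown here accounts for either step.

From the compounds shown here alone, what a different group at this aromatic carbon would do, such as an amine, a nitrile or a carboxylic acid, remains open. Also open, going by these compounds, is whether hydrogen would be tolerated equally well on the urea of compound 3, which differs from compound 4 in more than one place.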